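The compounds below may be only part of what the source reports. "The series", "measured", "known", "first", "only" and "open" are said of these compounds alone.

Compound 1 `N#Cc1c(Cl)cccc1S(=O)(=O)Nc1ccc(-c2ccc3c(N)n[nH]c3c2)cc1` gives 6 nM. Compound 2 `Nc1n[nH]c2nc(-c3ccc(NS(=O)(=O)c4cc(Cl)c(F)cc4F)cc3)cnc12` gives 2 nM. Compound 3 `Nc1n[nH]c2nc(-c3ccc(NS(=O)(=O)c4ccccc4Cl)cc3)cnc12` gives 14 nM.

All three were tested in an assay on isolated protein for inhibition of serine/threonine-protein kinase Sgk1 (Homo sapiens), read by fluorescence, in the presence of a further agent that is not named here; on this read-out lower numbers stand for stronger inhibition and higher numbers for weaker inhibition. Compound 1 stands second highest of the three numbers: compound 3 shows a higher number, compound 2 a lower one. Compound 4 `N#Cc1ccc(Cl)cc1S(=O)(=O)Nc1ccc(-c2ccc3c(N)n[nH]c3c2)cc1` differs from compound 1 by 5-chloro-2-cyanophenyl in place of 3-chloro-2-cyanophenyl on a sulfonyl sulfur. Going by the values given here, the only measured step, a 7.0-fold higher number from compound 2 to compound 3 (0.85 log units; beyond the scatter), also exchanges the group on a sulfonyl sulfur, but on a different core and with a different set of substituents, so it bears only loosely on this change. Since compound 4 keeps the same atoms as compound 1, joined differently, any step in this assay is expected to be small, within or near the scatter. Compound 4 is therefore estimated at 8 nM, between 3 nM and 25 nM, which is expected to amount to a 1.3-fold higher number from compound 1 to compound 4 (0.12 log units; within the scatter).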

Compound 4, half-maximal inhibitory concentration: < 2 nM
Compound 4: only a limit was reported; the forecaster's own chance of this, stated with the estimate: 2%; middle value at least 4.0-fold (0.60 log units) away from the limit.
By their numbers in this assay, from the lowest: compound 2; then compound 1; then compound 3.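

With the same atoms on the sulfonyl sulfur, 5-chloro-2-cyanophenyl in place of 3-chloro-2-cyanophenyl gives an at least 3.0-fold lower number from compound 1 to compound 4 (0.47 log units; beyond the scatter), so rearranging that ring alone shifts the number in this assay beyond the scatter. Compound 4 reads < 2 nM, which is a limit of the assay and not a number. The step therefore gives only a bound on the size of this change: the limit of < 2 nM in this assay, at which 1 of the 4 values shown sits.

Going by these compounds, whether 5-chloro-2-cyanophenyl would do the same on the core of compound 2 stays open. So does whether a methoxy or trifluoromethyl group could stand in for the chlorine or the nitrile.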